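A few compounds are considered here, and "the series" means these few. Any claim that something is new, unique, unknown or untested is made for them only; others in the source may bear on it.

Three compounds share one core and differ only in the group attached to the ring nitrogen of the triazole. Compound 1 `CC1(C)[C@H]2CC[C@]1(C)N(Cc1cn(-c3ccc(Cl)cc3)nn1)C(=O)C2` gives 160 nM in a functional assay on OVCAR-3 cells (Homo sapiens) for inhibition, read by MTT assay, with a stated time of 24 h; on this read-out lower numbers stand for stronger inhibition and higher numbers for weaker inhibition; compound 2 `Cc1ccccc1-n1cc(CN2C(=O)C[C@@H]3CC[C@@]2(C)C3(C)C)nn1` gives 150 nM, the lowest of the three numbers, though the step of a 1.1-fold lower number from compound 1 to compound 2 (0.03 log units; within the scatter) lies within the scatter; compound 3 `CC1(C)[C@H]2CC[C@]1(C)N(Cc1cn(-c3ccc(C#N)cc3)nn1)C(=O)C2` gives 380 nM. Compound 4 `CC1(C)[C@H]2CC[C@]1(C)N(Cc1cn(-c3ccc(O)cc3)nn1)C(=O)C2` is not yet measured; the change is 4-hydroxyphenyl in place of 2-methylphenyl on an aromatic nitrogen. For the measured compounds named here, two steps bear on it: a 2.5-fold higher number from compound 2 to compound 3 (0.40 log units; beyond the scatter) and a 2.4-fold higher number from compound 1 to compound 3 (0.38 log units; beyond the scatter), both modest rises when a 4-cyanophenyl arrived. A modest rise is therefore expected, a 2.0-fold higher number from compound 2 to compound 4 (0.30 log units; within the scatter). Compound 4 is estimated at 300 nM, within 120 nM to 750 nM.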

Compound 4, half-maximal inhibitory concentration: 410 nM
Estimate against measurement, compound 4: 1.4-fold (0.14 log units) below; the range from low to high includes it.
By their numbers in this assay, from the lowest: compounds 2 and 1 (each within the scatter of the next); then compounds 3 and 4 (each within the scatter of the next).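

In this assay, the 4-hydroxyphenyl group gives a modest rise, a 2.7-fold higher number from compound 2 to compound 4 (0.44 log units; beyond the scatter), and another against the 4-chlorophenyl group, a 2.6-fold higher number from compound 1 to compound 4 (0.41 log units; beyond the scatter). Replacing cyano with hydroxy makes no readable difference, a 1.1-fold higher number from compound 3 to compound 4 (0.03 log units; within the scatter), so two different groups now share the higher level. Compound 1 goes against any rule that a group in this place raises the number, as its chloro stays level with compound 2.

Nothing here explains why these groups separate. As far as these compounds go, it remains open whether an amine or a methoxy group on the same ring would fall with chloro or with hydroxy.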